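The compounds below may be only part of what the source reports. "The series", "measured", "known", "first", "only" and "open" are said of these compounds alone.

Measured compounds in a functional assay on MV4-11 cells (Homo sapiens) for antiproliferative activity, read by resazurin assay, with a stated time of 72 h; on this read-out lower numbers stand for stronger inhibition and higher numbers for weaker inhibition:
Compound 1 `N#Cc1c(-c2ccco2)nc2c(c(-c3ccccc3)nn2-c2ccccc2)c1-c1ccc(O)cc1`: 13800 nM
Compound 2 `COc1ccc(-c2nc3c(c(-c4ccccc4)nn3-c3ccccc3)c(-c3ccc(O)cc3)c2C#N)cc1`: 1600 nM
Compound 3 `N#Cc1c(-c2ccc(F)cc2)nc2c(c(-c3ccccc3)nn2-c2ccccc2)c1-c1ccc(O)cc1`: 11600 nM

Compound 1 and compound 3 lie together at the upper end of these three numbers; a 1.2-fold lower number from compound 1 to compound 3 (0.08 log units; within the scatter), which stays within the scatter. For the measured compounds named here, the only clearly separated value belongs to compound 2: an 8.6-fold lower number from compound 1 to compound 2 (0.94 log units; beyond the scatter), and in the same sense a 7.3-fold higher number from compound 2 to compound 3 (0.86 log units; beyond the scatter).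

Compound 4 `COc1cc(-c2c(C#N)c(-c3ccco3)nc3c2c(-c2ccccc2)nn3-c2ccccc2)ccc1O` differs from compound 1 by methoxy in place of hydrogen on an aromatic carbon. Going by the values given here, the three measured steps all concern the other aromatic substituent, the group on the carbon next to the nitrile; none of them touches the hydroxyphenyl ring that is altered here, so no measured step bears on this change. With nothing to point either way, the working assumption is a step from compound 1 to compound 4 that does not go beyond the scatter in this assay, in either direction. On these data alone, compound 4 is therefore expected at 12000 nM (range 4000 nM to 40000 nM), meaning an expected step of a 1.2-fold lower number from compound 1 to compound 4 (0.06 log units; within the scatter), with the range kept wide because this position is untested.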

Compound 4, half-maximal inhibitory concentration: 35300 nM
The estimate for compound 4 lay 2.9-fold (0.47 log units) below the measured number; low and high end bracket the measured number.
By their numbers in this assay, from the lowest: compound 2; then compounds 3 and 1 (each within the scatter of the next); then compound 4.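

The hydroxyphenyl ring responds to substitution in this assay: the change from 4-hydroxyphenyl to 4-hydroxy-3-methoxyphenyl gives a 2.6-fold higher number from compound 1 to compound 4 (0.41 log units; beyond the scatter) and moves the series toward weaker inhibition. For the compounds shown here, the earlier steps covered only the other aromatic substituent, so this is the first sign that a group ortho to the hydroxy group can shift the read-out, and here the shift is unfavourable. Nothing at hand accounts for this step.

On these data alone, it remains open whether this shift is specific to methoxy or would also follow from a different group at this place, such as an amine, a carboxylic acid or a longer alkoxy chain. As far as these compounds go, it is equally open whether the same change would carry the same penalty with the 4-methoxyphenyl group of compound 2 in place of furan-2-yl.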